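Notes on fluoro substitution in the dimethylamino series

A few compounds are considered here, and "the series" means these few. Any claim that something is new, unique, unknown or untested is made for them only; others in the source may bear on it.

Measured so far in an ADME assay on the whole organism (Mus musculus, strain CD-1) for pharmacokinetics, with a stated time of 6 h, at a dose of 10 mg/kg by the oral route; a lower number here means less compound in the circulation, a higher number more compound in the circulation at the dose given:
- compound 1 `Cc1c(C(=O)N2CC[C@H](N)C2)nc(-c2ccc(C#N)c(F)c2)n1-c1ccc2nn(C)cc2c1` gives 80 ng.h/mL
- compound 2 `Cc1c(C(=O)N2CC[C@H](N(C)C)C2)nc(-c2ccc(C#N)c(F)c2)n1-c1ccc2nn(C)cc2c1` gives 760 ng.h/mL

Among the compounds with values here, compound 2 stands highest of the two numbers at 760 ng.h/mL in this assay so far. Compound 3 `Cc1c(C(=O)N2CC[C@H](N(C)C)C2)nc(-c2ccc(C#N)c(F)c2)n1-c1cc(F)c2nn(C)cc2c1` differs from compound 2 by fluoro in place of hydrogen on an aromatic carbon with fluoro in place of hydrogen on an aromatic carbon, turning 2-methyl-2H-indazol-5-yl into 7-fluoro-2-methyl-2H-indazol-5-yl. Within the data shown here, the only measured step, a 9.5-fold higher number from compound 1 to compound 2 (0.98 log units; beyond the scatter) with dimethylamino in place of amino on a saturated ring carbon, is modest and lies elsewhere in the structure. Among the measured compounds shown here, no measured step tests a fluoro change, so no shift beyond the scatter is expected in either direction. The expected step is a 1.1-fold higher number from compound 2 to compound 3 (0.05 log units; within the scatter) as a working estimate. Compound 3 is estimated at 850 ng.h/mL with an expected range of 350 ng.h/mL to 2100 ng.h/mL in this series.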

Compound 3, area under the concentration-time curve: 660 ng.h/mL
Estimate against measurement, compound 3: 1.3-fold (0.11 log units) above; measured number inside the range.
By their numbers in this assay, from the lowest: compound 1; then compounds 3 and 2 (each within the scatter of the next).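

In this assay fluoro in place of hydrogen, turning 2-methyl-2H-indazol-5-yl into 7-fluoro-2-methyl-2H-indazol-5-yl, gives a 1.2-fold lower number from compound 2 to compound 3 (0.06 log units; within the scatter) and so leaves the number in the dimethylamino series within the scatter. Within the data shown here, this position therefore accepts fluoro without a readable change, whereas the only earlier step lay at the amine on the saturated ring. Nothing measured here bears on why the number stays put.

On these data alone, whether a chloro, methoxy or amino group at this position would shift the number remains open. So does whether fluoro behaves the same with the primary amino group of compound 1.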